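From (isopropylcarbamoyl)amino to carboxymethyl on the shared core

The compounds below may be only part of what the source reports. "The series", "measured", "known", "first", "only" and "open" are said of these compounds alone.

Compound 1 `COc1ccc(-c2nc(CNC(C)=O)sc2-c2ccc(OC)cc2)cc1` gives 15 nM in a functional assay with Oryctolagus cuniculus as the target; a lower number here means a stronger inhibitor, a higher number a weaker inhibitor. Compound 2 `COc1ccc(-c2nc(CNC(=O)CSc3ccccc3)sc2-c2ccc(OC)cc2)cc1` gives only a limit, < 100 nM. Compound 3 `COc1ccc(-c2nc(CNC(=O)NC(C)C)sc2-c2ccc(OC)cc2)cc1` gives 42 nM.

Among the two numbers shown, compound 3 has the higher one; its nearest neighbour is compound 1, with a 2.8-fold higher number from compound 1 to compound 3 (0.45 log units; beyond the scatter). Compound 2 sits at the limit of < 100 nM in this assay, at which 1 of the 3 values shown sits, so a step that the limit leaves unreadable from compound 1 to compound 2 and a step that the limit leaves unreadable from compound 2 to compound 3 cannot be sized.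

Compound 4 `COc1ccc(-c2nc(CCC(=O)O)sc2-c2ccc(OC)cc2)cc1` differs from compound 3 by carboxymethyl in place of (isopropylcarbamoyl)amino on a saturated chain carbon bound to an aromatic carbon. Within the data shown here, no measured step bears on this change directly: the step from compound 1 to compound 3 exchanges only the substituent on a carbonyl carbon, whereas here the whole (isopropylcarbamoyl)amino group leaves and a carboxymethyl enters, giving 2-carboxyethyl on the core. Among the measured compounds shown here, with no precedent for an acid at this position, the expectation is wide and leans toward a weaker inhibitor. Compound 4 is therefore estimated at 150 nM, between 30 nM and 800 nM, which would mean a 3.6-fold higher number from compound 3 to compound 4 (0.55 log units; beyond the scatter).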

Compound 4, half-maximal inhibitory concentration: < 100 nM
Compound 4: no number, only a limit (the forecaster's own chance of this, stated with the estimate: 15%); middle value at least 1.5-fold (0.17 log units) away from the limit.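

In this assay compound 4 gives only a limit of < 100 nM and so its steps from compound 1, compound 2 and compound 3 cannot be read. The compounds shown leave open whether carboxymethyl in place of (isopropylcarbamoyl)amino makes compound 4 a stronger or weaker inhibitor than compound 3.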